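From trifluoromethyl to methoxy in a growth inhibition assay

A few compounds are considered here, and "the series" means these few. Any claim that something is new, unique, unknown or untested is made for them only; others in the source may bear on it.

Among the compounds with values here, in a functional assay on NCI/ADR-RES cells (Homo sapiens) for inhibition, read by sulforhodamine B assay, with a stated time of 48 h (a lower number here means a stronger inhibitor of growth, a higher number a weaker inhibitor of growth), compound 1 `CC1(/C=C/c2ccc(C(F)(F)F)cc2)C=CC(=O)O1` gives 9400 nM, the lower of the two numbers so far and beyond the scatter of compound 2 `COc1cc(/C=C/C2(C)C=CC(=O)O2)cc(OC)c1OC`, which gives 123000 nM. Compound 3 `COc1ccc(/C=C/C2(C)C=CC(=O)O2)cc1` has methoxy in place of trifluoromethyl on an aromatic carbon. Within the data shown here, no measured step isolates this change. A move towards a weaker inhibitor of growth is expected, resting on compound 2, which also carries methoxy and gives 123000 nM. The expected step is a 3.2-fold higher number from compound 1 to compound 3 (0.50 log units; beyond the scatter), beyond the scatter. For compound 3 the estimated value is 30000 nM, with an expected range of 10000 nM to 90000 nM.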

Compound 3, concentration for total growth inhibition: > 1000000 nM
Compound 3 was reported as a limit; the forecaster's own chance of this, stated with the estimate: 10%; at least 33-fold (1.52 log units) between middle value and limit.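

Within the data shown here, replacing trifluoromethyl with methoxy on this aromatic carbon gives the first reading in this assay of this change in isolation, an at least 100-fold higher number from compound 1 to compound 3 (2.02 log units; beyond the scatter), so this position is far from indifferent to the group it carries. The figure for compound 3 is a limit and not a number, which leaves the full size of the step unknown: the limit of > 1000000 nM in this assay, at which 1 of the 3 values shown sits.

The compounds shown do not tell whether the outcome follows from losing trifluoromethyl or from gaining methoxy. A chlorine, a nitrile or a plain hydrogen at this place would separate the two.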